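The source may report more compounds than this note shows. Statements on the series, on what has been measured and on what is new or still open speak of the compounds shown alone.

Of the compounds shown here, three built on one shared core have been measured in an assay (Rattus norvegicus) for inhibition of Fatty-acid amide hydrolase 1 (Homo sapiens); on this read-out higher numbers stand for weaker inhibition and lower numbers for stronger inhibition. Compound 1 `N#Cc1ccccc1-c1cnc(C(=O)CCCCCCc2ccccc2)o1` gives 130 nM, and compound 2 `Cc1ccc(-c2cnc(C(=O)CCCCCCc3ccccc3)o2)nc1` gives 2.8 nM; between them stands a 46-fold lower number from compound 1 to compound 2 (1.67 log units; beyond the scatter). For compound 3 `O=C(CCCCCCc1ccccc1)c1ncc(-c2ncccc2C(=O)O)o1` this assay reports only a limit, > 50 nM, not a number. The measured steps that reach compound 3 are an at least 17-fold higher number from compound 2 to compound 3 (1.25 log units; beyond the scatter) and a step that the limit leaves unreadable from compound 1 to compound 3. Compound 4 `CN1CCN(C(=O)c2cnc(C(=O)CCCCCCc3ccccc3)o2)CC1` is not yet measured; it differs from compound 3 in one place: (4-methylpiperazin-1-yl)carbonyl in place of 3-carboxypyridin-2-yl on an aromatic carbon. Because an at least 17-fold higher number from compound 2 to compound 3 (1.25 log units; beyond the scatter) followed the entry of 3-carboxypyridin-2-yl, its departure in compound 4 is expected to give a lower number, an at least 1.6-fold lower number from compound 3 to compound 4 (0.22 log units; that floor lies within the scatter). Compound 4 is therefore estimated at 30 nM, within a range from 5 nM to 200 nM.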

Compound 4, inhibition constant: 80 nM
Beside the measured number, compound 4's estimate is 2.7-fold (0.43 log units) below it; measured number inside the range.
By their numbers in this assay, from the lowest: compound 2; then compounds 4 and 1 (each within the scatter of the next).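

Swapping 2-cyanophenyl for (4-methylpiperazin-1-yl)carbonyl, which has a non-aromatic ring, gives a 1.6-fold lower number from compound 1 to compound 4 (0.21 log units; within the scatter), so at this position an aromatic ring on the shared core is not required to match compound 1. The same group in place of 5-methylpyridin-2-yl gives a 29-fold higher number from compound 2 to compound 4 (1.46 log units; beyond the scatter), so it does not reach the low number of compound 2. Compound 3 has only a limit, so its step to compound 4 cannot be read: the limit of > 50 nM in this assay, at which 1 of the 4 values shown sits.

Left open is where an open-chain amine or a morpholine carbonyl would fall at this position. Also open, going by these compounds, is which part of 5-methylpyridin-2-yl goes with the low number of compound 2.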